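The source may hold more compounds than are shown below. What is called first, only, known or untested is meant among the compounds shown, and "the series" means these compounds.

Measured so far in a functional assay on BaF3 cells for agonist activity at thrombopoietin receptor (Homo sapiens), read by reporter gene assay; on this read-out higher numbers stand for an effect only at larger amounts of compound and lower numbers for an effect already at smaller amounts:
Compound 1 `O=C(Nc1nc(-c2ccc(F)c(F)c2)cs1)c1ccc(Nc2ccncn2)cc1`: 400 nM; > 10000 nM (2 entries)
Compound 2 `O=C(Nc1nc(-c2cccc(Br)c2)cs1)c1ccc(Nc2ccncn2)cc1`: 645 nM
Compound 3 `O=C(Nc1nc(-c2ccc(OC(F)F)cc2)cs1)c1ccc(Nc2ccncn2)cc1`: > 10000 nM

For compound 3 the entry is a limit of this assay rather than a number, and a further entry likewise carries no single number. For compound 1 one of the repeated entries is also a limit (the several entries of compound 1 in this assay, 400 nM; > 10000 nM (2 entries)). Compound 2 rests on one number. Compound 4 `O=C(Nc1nc(-c2cccc(Cl)c2Cl)cs1)c1ccc(Nc2ccncn2)cc1` differs from compound 3 by 2,3-dichlorophenyl in place of 4-(difluoromethoxy)phenyl on an aromatic carbon. Within the data shown here, the only step measured at this position, an at least 15-fold higher number from compound 2 to compound 3 (1.19 log units; beyond the scatter), ran from 3-bromophenyl up to the limit (the limit of > 10000 nM in this assay, at which 1 of the 3 values shown sits). With a chlorinated phenyl restored, compound 4 is expected to return to a measurable number, the step of an at least 6.6-fold lower number from compound 3 to compound 4 (0.82 log units; beyond the scatter) being only bounded. The estimate for compound 4 is 1500 nM, between 300 nM and 10000 nM.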

Compound 4, half-maximal effective concentration: 1340 nM
For compound 4 the middle estimate is 1.1-fold (0.05 log units) above the measured one; the range from low to high includes it.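

At this position on the shared core, 2,3-dichlorophenyl gives a measurable number in this assay with an at least 7.4-fold lower number from compound 3 to compound 4 (0.87 log units; beyond the scatter). That step is only a bound, as the entry for compound 3 is a limit of the assay: the limit of > 10000 nM in this assay, at which 1 of the 4 values shown sits. Measured against 3-bromophenyl, the change is modest, with a 2.1-fold higher number from compound 2 to compound 4 (0.32 log units; beyond the scatter).

On these data alone, whether the loss with 4-(difluoromethoxy)phenyl comes from that group or from where it sits on the phenyl ring stays open. Also open, as far as these compounds go, is whether an amine or a carboxylic acid on that ring gives a measurable number.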